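The source may hold more compounds than are shown below. What is called first, only, known or untested is meant among the compounds shown, and "the series" means these compounds.

- compound 1 `COc1ccc(C(=O)N(Cc2ccncc2)Cc2cccc(OCC3CCOCC3)c2)cc1` at 17700 nM
- compound 2 `COc1ccc(C(=O)N(Cc2ccncc2)Cc2cccc(OCc3ccc([N+](=O)[O-])cc3)c2)cc1` at 15400 nM

In a functional assay on KMS-11 cells (Homo sapiens) for antiproliferative activity, read by CellTiter-Glo, with a stated time of 72 h (a higher number here means a weaker inhibitor, a lower number a stronger inhibitor), compound 2 stands at 15400 nM and is level with compound 1, the step being a 1.1-fold lower number from compound 1 to compound 2 (0.06 log units; within the scatter) and so no real separation. Compound 3 `COc1ccc(C(=O)N(Cc2ccncc2)Cc2cccc(OCc3ccc(C(F)(F)F)cc3)c2)cc1` differs from compound 2 in one group: trifluoromethyl in place of nitro on an aromatic carbon puts trifluoromethyl in place of nitro on an aromatic carbon. Among the measured compounds shown here, the only measured step bearing on this is the one above, where 4-nitrophenyl replaced oxan-4-yl and the number stayed within the scatter. The expected result is a 1.1-fold lower number from compound 2 to compound 3 (0.04 log units; within the scatter) and no shift beyond the scatter. Compound 3 is estimated at 14000 nM with an expected range from 6000 nM to 28000 nM as the likely span.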

Compound 3, half-maximal inhibitory concentration: 14300 nM
The estimate for compound 3 lay 1.0-fold (0.01 log units) below the measured number; measured number inside the range.
By their numbers in this assay, from the lowest: compounds 3, 2 and 1 (each within the scatter of the next).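

In this assay, trifluoromethyl in place of nitro on an aromatic carbon, para to a large group, leaves the number level (a 1.1-fold lower number from compound 2 to compound 3 (0.03 log units; within the scatter)), so two different substituents at this position show no separation. Replacing oxan-4-yl with 4-(trifluoromethyl)phenyl also stays within the scatter (a 1.2-fold lower number from compound 1 to compound 3 (0.09 log units; within the scatter)), so all three end groups now read alike. No evidence here accounts for this flatness.

Going by these compounds, whether an amine or a carboxylic acid in place of trifluoromethyl would move the number beyond the scatter remains open. So does whether any change elsewhere on the shared core would do so.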